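A few compounds are considered here, and "the series" means these few. Any claim that something is new, unique, unknown or untested is made for them only; others in the source may bear on it.

Compound 1 `CN1CCN(C[C@H]2CN(c3ccc(-n4cc(-c5ccccn5)cn4)c(F)c3)C(=O)O2)CC1`: 1690000 nM
Compound 2 `O=C1CCC(=O)N1C[C@H]1CN(c2ccc(-n3cc(-c4ccccn4)cn3)c(F)c2)C(=O)O1`: 45300 nM

In a physicochemical assay for solubility, read by HPLC, with a stated time of 24 h (on this read-out lower numbers stand for lower solubility and higher numbers for higher solubility), compound 1 gives 1690000 nM, the highest of the two numbers measured; its nearest neighbour, compound 2, gives 45300 nM. Compound 3 `CC(=O)OC[C@H]1CN(c2ccc(-n3cc(-c4ccccn4)cn3)c(F)c2)C(=O)O1` is not yet measured. It differs from compound 1 in one place: acetoxy in place of 4-methylpiperazin-1-yl on a saturated chain carbon bound to a saturated ring carbon.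

Within the data shown here, one measured step bears on this change. Going a 37-fold lower number from compound 1 to compound 2 (1.57 log units; beyond the scatter), the 4-methylpiperazin-1-yl group was replaced on the same saturated chain carbon, and the number fell steeply. The group entering in compound 3, acetoxy, is likewise a neutral group without a ring, so a drop of comparable size is expected for compound 3, with the step of a 28-fold lower number from compound 1 to compound 3 (1.45 log units; beyond the scatter) anticipated. Compound 3 is therefore estimated to give 60000 nM in this assay, with a range from 15000 nM to 250000 nM.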

Compound 3, solubility: 373000 nM
Estimate against measurement, compound 3: 6.2-fold (0.79 log units) below; measured number above the stated range.
By their numbers in this assay, from the lowest: compound 2; then compound 3; then compound 1.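

At this saturated chain carbon bound to a saturated ring carbon, the fall in this assay on losing 4-methylpiperazin-1-yl proves to depend strongly on the group that enters: acetoxy gives a 4.5-fold lower number from compound 1 to compound 3 (0.66 log units; beyond the scatter), a far smaller step than the one seen earlier with 2,5-dioxopyrrolidin-1-yl. The two entering groups are also clearly separated from each other, with an 8.2-fold higher number from compound 2 to compound 3 (0.92 log units; beyond the scatter), so removing 4-methylpiperazin-1-yl does not by itself set the level reached. No measurement here accounts for the difference between acetoxy and 2,5-dioxopyrrolidin-1-yl.

The compounds shown leave open where an open-chain amine such as dimethylamino, or a carboxylic acid, on this same chain carbon would fall relative to compound 1 and compound 3. They also leave open whether a hydroxyl group would stand closer to acetoxy or to 2,5-dioxopyrrolidin-1-yl.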